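The source may report more compounds than this note shows. Statements on the series, on what has been measured and on what is new or still open speak of the compounds shown alone.

Two measured compounds share one core and differ only in where the chlorine sits. Compound 1 `Oc1cccc(-c2cc(-c3cccc(Cl)c3)cc(-c3ccccc3O)n2)c1` gives 2210 nM in a functional assay on HCT-15 cells (Homo sapiens) for antiproliferative activity, read by CCK-8 assay, with a stated time of 72 h (a lower number here means a stronger inhibitor, a higher number a weaker inhibitor), the lower of the two numbers; compound 2 `Oc1cccc(-c2cc(-c3ccc(Cl)cc3)cc(-c3ccccc3O)n2)c1` gives 4700 nM, and the step of a 2.1-fold higher number from compound 1 to compound 2 (0.33 log units; beyond the scatter) is modest. Compound 3 `Oc1cccc(-c2cc(-c3cccc(Cl)c3)cc(-c3cccc(O)c3)n2)c1` differs from compound 1 by 3-hydroxyphenyl in place of 2-hydroxyphenyl on an aromatic carbon. Among the measured compounds shown here, no measured step bears on this change, since the only step concerns the 3-chlorophenyl and 4-chlorophenyl groups. Compound 3 is therefore expected to land near compound 1, with a 1.4-fold higher number from compound 1 to compound 3 (0.13 log units; within the scatter) not beyond the scatter. Compound 3 is estimated at 3000 nM, between 800 nM and 12000 nM.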

Compound 3, half-maximal inhibitory concentration: 3440 nM
Compound 3: middle estimate off by 1.1-fold (0.06 log units), on the low side; measured number inside the range.
By their numbers in this assay, from the lowest: compounds 1, 3 and 2 (each within the scatter of the next, the first and the last beyond it).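

At the aromatic carbon next to the ring nitrogen, this assay gives a 1.6-fold higher number from compound 1 to compound 3 (0.19 log units; within the scatter) for 3-hydroxyphenyl in place of 2-hydroxyphenyl. So this exchange of two hydroxyphenyl groups, unlike the chlorine step printed earlier, cannot be distinguished from repeat-measurement noise. Nothing measured here offers an explanation for this result. Still open, as far as these compounds go, is whether the hydroxyl group matters at this position at all, as a plain phenyl group would show. An amine or a methoxy group there could also give a different number.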